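Series notes: compound 4 against its measured relatives

The source may report more compounds than this note shows. Statements on the series, on what has been measured and on what is new or still open speak of the compounds shown alone.

Measured so far:
- compound 1 `COc1ccccc1/C=c1/[nH]c(=O)/c(=C\c2ccccc2OC)n(C)c1=O`: 2200 nM
- compound 2 `C=CCn1c(=O)/c(=C\c2ccc(Cl)c(Cl)c2)[nH]c(=O)/c1=C\c1ccccc1OC`: "not active" (no number reported)
- compound 3 `COc1ccccc1/C=c1\c(=O)[nH]/c(=C/c2cccc(Cl)c2Cl)c(=O)n1C`: 110 nM

In a functional assay on K562 cells (Homo sapiens) for cytotoxicity, read by CCK-8 assay, with a stated time of 72 h (a higher number here means a weaker inhibitor, a lower number a stronger inhibitor), compound 1 gives 2200 nM, and compound 3 gives 110 nM. Among the measured compounds shown here, the one step between compounds that differ in a single place is a 20-fold lower number from compound 1 to compound 3 (1.30 log units; beyond the scatter). Compound 2 stands apart: in this assay compound 2 is given as "not active" (no number reported), with no number, so its position relative to compound 1 and compound 3 cannot be placed on the scale.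

Compound 4 `C=CCn1c(=O)/c(=C\c2ccc(C)cc2)[nH]c(=O)/c1=C\c1ccccc1OC` differs from compound 2 by 4-methylphenyl in place of 3,4-dichlorophenyl on a double-bonded chain carbon bound to an aromatic carbon. For the measured compounds named here, no measured step bears on this exchange: the step from compound 1 to compound 3 concerns a different dichloro pattern entering in place of a methoxy group, and nothing measured covers a methylphenyl. With compound 2 inactive and compound 1 as the nearest numbered relative, compound 4 is expected to be weak in this assay, with a wide range and a real chance of another limit-only result. The estimate for compound 4 is 6000 nM, within 800 nM to 40000 nM.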

Compound 4, half-maximal inhibitory concentration: "not active" (no number reported)
Compound 4 has no reported number here; no gap can be computed for the estimate.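

In this assay compound 2 and compound 4 are both reported as not active with no number, so no step can be read between them. The compounds shown leave open how 4-methylphenyl and 3,4-dichlorophenyl compare at this place. Nothing at hand accounts for either result.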